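A few compounds are considered here, and "the series" means these few. Any claim that something is new, unique, unknown or untested is made for them only; others in the source may bear on it.

Compound 3 `CCCCNc1cnc(C(=O)NCc2ccccc2)cn1` is the reference for this step. In an ADME assay on HEL cells (Homo sapiens) for cytotoxicity, read by microscopy, with a stated time of 6 days (on this read-out higher numbers stand for lower toxicity in this test and lower numbers for higher toxicity in this test), compound 3 gives > 100000 nM, which is a limit of the assay and not a number. The two further values on the shared core are of the same kind. Compound 1 `CCCCCNc1cnc(C(=O)NCc2ccccc2)cn1` gives > 100000 nM in this assay, again a limit. Compound 2 `CCCCCCNc1cnc(C(=O)NCc2ccccc2)cn1` gives > 100000 nM in this assay, also a limit. Going by the values given here, because of the limit of > 100000 nM in this assay, at which 3 of the 3 values shown sit, none of the measured steps can be read: a step that the two limits leave unreadable from compound 1 to compound 3, a step that the two limits leave unreadable from compound 2 to compound 3 and a step that the two limits leave unreadable from compound 1 to compound 2 are all hidden between two limits, so neither direction nor size is available for the chain-length changes seen so far.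

Compound 4 `CCCCCCCCNc1cnc(C(=O)NCc2ccccc2)cn1` carries the change (butyl in place of hydrogen on a saturated chain carbon, four bonds along the chain from a nitrogen on an aromatic ring). The three measured steps bear on it only in that lengthening or shortening the chain by one or two carbons has never moved a value off the limit, and the same is expected here. The step from compound 3 to compound 4 is therefore estimated as a number no higher from compound 3 to compound 4 (the limit leaves the size open), that is, no step beyond the scatter. For compound 4 the estimate in this assay is 100000 nM, with a range from 30000 nM to 300000 nM, and most likely another limit rather than a number.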

Compound 4, minimum cytotoxic concentration: 100000 nM
Compound 4: middle estimate and measured number agree at the digits printed; measured number inside the range.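

In this assay, going by these compounds alone, compound 4 gives 100000 nM, a number and not a limit, and the first such value on the shared core. With butyl in place of hydrogen at this position on the saturated chain, four bonds along from the nitrogen on the aromatic ring, the result reads as a number no higher from compound 3 to compound 4 (the limit leaves the size open), as a number no higher from compound 2 to compound 4 (the limit leaves the size open) and as a number no higher from compound 1 to compound 4 (the limit leaves the size open). The direction of these steps is bounded but their size stays closed, and the steps among compound 1, compound 2 and compound 3 cannot be read at all, because the shorter chains all rest on the limit: the limit of > 100000 nM in this assay, at which 3 of the 4 values shown sit.

As far as these compounds go, whether a still longer chain than that of compound 4 would bring the value clearly down in this assay stays open, so no trend with chain length can yet be stated. Also open, from the compounds shown here alone, is what an amine or a carboxylic acid in place of the butyl would give in this assay.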